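Ester Variation at the Hydroxyethyl Side Chain of a Shared Core

A few compounds are considered here, and "the series" means these few. Any claim that something is new, unique, unknown or untested is made for them only; others in the source may bear on it.

Measured compounds:
- Compound 1: `O=c1[nH]c2ccc(Cl)cc2c(-c2ccccc2Cl)c1CCO` — 380000 nM
- Compound 2: `CC(=O)NCC(=O)OCCc1c(-c2ccccc2Cl)c2cc(Cl)ccc2[nH]c1=O` — 110000 nM
- Compound 3: `O=C(OCCc1c(-c2ccccc2Cl)c2cc(Cl)ccc2[nH]c1=O)c1ccc([N+](=O)[O-])cc1` — 1600000 nM

Three compounds share one core and differ only at the oxygen on the saturated carbon of the side chain. In an ADME assay on HepG2 2.2.15 cells (Homo sapiens) for cytotoxicity (on this read-out lower numbers stand for higher toxicity in this test and higher numbers for lower toxicity in this test), compound 1 gives 380000 nM. Compound 2 carries an (acetamidomethyl)carbonyl there and gives 110000 nM, while compound 3 carries a (4-nitrophenyl)carbonyl and gives 1600000 nM, the highest number of the three. The measured steps are a 3.5-fold lower number from compound 1 to compound 2 (0.54 log units; beyond the scatter), a 4.2-fold higher number from compound 1 to compound 3 (0.62 log units; beyond the scatter) and a 15-fold higher number from compound 2 to compound 3 (1.16 log units; beyond the scatter).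

Compound 4 is `C/C=C(\C)C(=O)OCCc1c(-c2ccccc2Cl)c2cc(Cl)ccc2[nH]c1=O` and has not yet been measured. It differs from compound 3 in one place: 1-methylprop-1-en-1-yl in place of 4-nitrophenyl on a carbonyl carbon. The step from compound 2 to compound 3 bears most directly on this change, since both replace one group on the carbonyl carbon; it was large, and the step from compound 1 to compound 3 was modest. Since compound 4 loses the aromatic ring and both acceptors of the 4-nitrophenyl group while keeping an ester, a moderate step downward from compound 3 is expected in this assay, estimated as a 3.2-fold lower number from compound 3 to compound 4 (0.51 log units; beyond the scatter). For compound 4 the expected value is 500000 nM, with a range from 150000 nM to 1600000 nM.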

Compound 4, half-maximal cytotoxic concentration: 350000 nM
For compound 4 the middle estimate is 1.4-fold (0.15 log units) above the measured one, within the range that was stated.
By their numbers in this assay, from the lowest: compound 2; then compounds 4 and 1 (each within the scatter of the next); then compound 3.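

The two earlier esters left it possible that any acyl group on this oxygen shifts the number, but in this assay the change from hydroxyl to the (1-methylprop-1-en-1-yl)carbonyl ester gives a 1.1-fold lower number from compound 1 to compound 4 (0.04 log units; within the scatter) and so shows that an ester here need not shift it. The differences among the esters therefore follow the group on the carbonyl carbon: 1-methylprop-1-en-1-yl in place of 4-nitrophenyl gives a 4.6-fold lower number from compound 3 to compound 4 (0.66 log units; beyond the scatter) while the same group in place of acetamidomethyl gives a 3.2-fold higher number from compound 2 to compound 4 (0.50 log units; beyond the scatter) and this places the new ester apart from both earlier ones, between them. Nothing measured here says why these esters differ.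

The compounds shown cannot tell whether the high number of compound 3 goes with its aromatic ring or with its nitro group, a question that an unsubstituted phenyl on the carbonyl carbon would address. They also leave open how a saturated butyl chain, an amine or a carboxylic acid carried on that carbonyl carbon would compare with the three esters in this assay and with the free hydroxyl of compound 1.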